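The compounds below may be only part of what the source reports. "The series", "measured", "known", "first", "only" and "open" are said of these compounds alone.

Three compounds of a shared core with two aziridin-1-yl groups have been tested in a functional assay on L1210 cells (Mus musculus), with a stated time of 12 days; a higher number here means a more potent compound, by a factor of ten per unit of this negative logarithm, a lower number a less potent compound. Compound 1 `CCCC1=C(N2CC2)C(=O)C(C(COC(N)=O)OC)=C(N2CC2)C1=O` gives 5.63. Compound 2 `O=C1C(CCO)=C(N2CC2)C(=O)C(CCO)=C1N1CC1` gives 6.54. Compound 3 `CC1=C(N2CC2)C(=O)C(CCCOC(N)=O)=C(N2CC2)C1=O` gives 6.18, which stands second highest of the three: compound 2 lies above it beyond the scatter, and compound 1 lies below it beyond the scatter.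

Compound 4 `CC1=C(N2CC2)C(=O)C(C(C)COC(N)=O)=C(N2CC2)C1=O` is not yet measured. It differs from compound 3 in one place, the two having the same atoms joined differently: a group of 7 heavy atoms (4 carbon, 1 nitrogen, 2 oxygen; no ring) in place of a group of 7 heavy atoms (4 carbon, 1 nitrogen, 2 oxygen; no ring), on a double-bonded ring carbon. For the measured compounds named here, no step between measured compounds resembles this rearrangement, so the size of the step from compound 3 to compound 4 is uncertain. Compound 4 is expected to reach about 6, within 5.5 to 6.5, the expected step of a number 0.18 log units lower from compound 3 to compound 4 (within the scatter) being small and, most likely, not beyond the scatter.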

Compound 4, logarithm of the reciprocal of the active concentration, log(1/C): 6.41
Compound 4: the middle estimate sits 0.41 log units below what was measured; the measured number falls inside the stated range.
By their numbers in this assay, from the lowest: compound 1; then compounds 3, 4 and 2 (each within the scatter of the next, the first and the last beyond it).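

In this assay, for the compounds shown here, joining the same atoms differently within the group of 7 heavy atoms on the double-bonded ring carbon gives a number 0.23 log units higher from compound 3 to compound 4 (within the scatter), the first comparison at this position that differs in one place only. At this position, this rearrangement therefore leaves no change that can be told from the scatter. Nothing at hand explains the result. The compounds shown leave open how a longer chain, an amine or a carboxylic acid on this ring carbon would compare.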